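Extending an Ether Chain Toward a Phenyl Ring

The source may report more compounds than this note shows. Statements on the series, on what has been measured and on what is new or still open speak of the compounds shown alone.

Compound 1 `CCOc1ccc2c(Cl)ccnc2c1` was tested in a functional assay on HepG2 cells (Homo sapiens) for cytotoxicity, read by MTT assay, with a stated time of 48 h (on this read-out lower numbers stand for stronger inhibition and higher numbers for weaker inhibition), where compound 1 gives 2660 nM. Among the three compounds measured, compound 1 holds the second highest number. Its nearest neighbour is compound 3 `Clc1ccnc2cc(OCc3ccccc3)ccc12`, which in this assay gives 2680 nM, and the furthest is compound 2 `CC(C)Oc1ccc2c(Cl)ccnc2c1`, which in this assay gives 2050 nM. Compound 4 `Clc1ccnc2cc(OCCc3ccccc3)ccc12` has not yet been measured. It differs from compound 1 in one place: phenyl in place of hydrogen on a saturated chain carbon, two bonds along the chain from an oxygen on an aromatic ring. For the measured compounds named here, two measured steps bear on this change, both at the saturated chain carbon bound to an oxygen on an aromatic ring. The change from compound 1 to compound 2 gave a 1.3-fold lower number from compound 1 to compound 2 (0.11 log units; within the scatter), and the change from compound 1 to compound 3 gave a 1.0-fold higher number from compound 1 to compound 3 (0.00 log units; within the scatter). Putting a methyl or a phenyl onto this chain has so far left the number where it was, within the scatter. The same is therefore expected here. Compound 4 is estimated to give 2500 nM, with a range from 1200 nM to 5500 nM. The expected step from compound 1 to compound 4 is a 1.1-fold lower number from compound 1 to compound 4 (0.03 log units; within the scatter), nothing beyond the scatter.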

Compound 4, half-maximal inhibitory concentration: 3310 nM
The estimate for compound 4 lay 1.3-fold (0.12 log units) below the measured number; the measured number falls inside the stated range.
By their numbers in this assay, from the lowest: compounds 2, 1, 3 and 4 (each within the scatter of the next).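

In this assay the new step is a 1.2-fold higher number from compound 1 to compound 4 (0.09 log units; within the scatter) and it adds a second place on the chain: a phenyl on the saturated chain carbon two bonds along from the oxygen leaves the number within the scatter of compound 1. Read with a 1.0-fold higher number from compound 1 to compound 3 (0.00 log units; within the scatter) and the same holds for a phenyl at either of these two chain carbons, so among the compounds shown, neither placing moves the number beyond the scatter. No measurement here says why the number holds so steady.

Open, going by these compounds, is whether any group at this chain carbon can shift the number beyond the scatter, since only a phenyl has been seen there. An amine or a carboxylic acid at the end of the chain would test this.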